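This account rests on a few compounds, and the source may have more. Where it says the series, first, only, none or still open, it means among the compounds named here.

The set holds four close relatives. Compound 1 `Nc1nnc(SC[C@H]2O[C@@H](OCc3noc(-c4ccc(Cl)cc4)n3)[C@@H]3OC4(CCCC4)O[C@@H]32)s1` gives 18000 nM in a functional assay on T47D cells (Homo sapiens) for antiproliferative activity, read by sulforhodamine B assay, with a stated time of 48 h; a higher number here means a weaker inhibitor of growth, a lower number a stronger inhibitor of growth. Compound 3 `CC(=O)OC[C@H]1O[C@@H](OCc2noc(-c3ccc([N+](=O)[O-])cc3)n2)[C@@H]2OC3(CCCC3)O[C@@H]21` gives 52000 nM in this assay. Compound 2 `CC1(C)O[C@H]2[C@H](OCc3noc(-c4ccc([N+](=O)[O-])cc4)n3)O[C@H](CSc3ncn[nH]3)[C@H]2O1` returns only a limit in this assay, > 100000 nM, so it stands at the limit of > 100000 nM in this assay, at which 1 of the 3 values shown sits, and no number fixes its place. Compound 4 `CC1(C)O[C@H]2[C@H](OCc3noc(-c4ccc([N+](=O)[O-])cc4)n3)O[C@H](CO)[C@H]2O1` differs from compound 2 in one place: hydroxy in place of (1H-1,2,4-triazol-5-yl)sulfanyl on a saturated chain carbon bound to a saturated ring carbon. Among the measured compounds shown here, no measured pair in this set walks the same change, so its size is unknown; with compound 2 at a limit, the expected step of a number no higher from compound 2 to compound 4 (the limit leaves the size open) is put close to none beyond the scatter. Compound 4 is therefore estimated at 100000 nM in this assay, between 30000 nM and 300000 nM, with a real chance that only a limit is reported again.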

Compound 4, concentration for 50% growth inhibition: > 100000 nM
Compound 4 was reported as a limit; the forecaster's own chance of this, stated with the estimate: 60%; the middle value sits exactly at the limit.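

Compound 2 and compound 4 both return only a limit, so no step can be read between them: the limit of > 100000 nM in this assay, at which 2 of the 4 values shown sit.
How far hydroxy in place of (1H-1,2,4-triazol-5-yl)sulfanyl shifts the result in this assay stays open for the compounds shown.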